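Fluoro on the phenylsulfanyl group of compound 3

A few compounds are considered here, and "the series" means these few. Any claim that something is new, unique, unknown or untested is made for them only; others in the source may bear on it.

In a functional assay on MCF7 cells (Homo sapiens) for antiproliferative activity, read by sulforhodamine B assay, with a stated time of 3 days (on this read-out lower numbers stand for stronger inhibition and higher numbers for weaker inhibition), compound 3 `c1ccc(Sc2ncnc3c2ncn3C2COc3ccccc3CO2)cc1` gives 7120 nM, within the scatter of compound 1 `c1ccc2c(c1)COC(n1cnc3c(OCC4CCCCC4)ncnc31)CO2` at 11600 nM and of compound 2 `Clc1ccc(Sc2ncnc3c2ncn3C2COc3ccccc3CO2)c(Cl)c1` at 12000 nM. Compound 4 `Fc1ccc(Sc2ncnc3c2ncn3C2COc3ccccc3CO2)cc1` differs from compound 3 by fluoro in place of hydrogen on an aromatic carbon, para to a large group. The closest evidence is the change on the sulfur-bound ring, a 1.7-fold lower number from compound 2 to compound 3 (0.23 log units; within the scatter). The other two steps, a 1.0-fold higher number from compound 1 to compound 2 (0.01 log units; within the scatter) and a 1.6-fold lower number from compound 1 to compound 3 (0.21 log units; within the scatter), also bear on this position. Within the data shown here, no measured step isolates a single fluoro. No step beyond the scatter is expected in this assay. The expected step is a 1.1-fold higher number from compound 3 to compound 4 (0.02 log units; within the scatter). For compound 4, the estimated value is 7500 nM, with an expected range of 3800 nM to 14000 nM.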

Compound 4, half-maximal inhibitory concentration: 11200 nM
Beside the measured number, compound 4's estimate is 1.5-fold (0.17 log units) below it; measured number inside the range.
By their numbers in this assay, from the lowest: compounds 3, 4, 1 and 2 (each within the scatter of the next).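

Fluoro on the phenylsulfanyl ring, para to a large group, now has a single-change reading, a 1.6-fold higher number from compound 3 to compound 4 (0.20 log units; within the scatter), in this assay. 4-Fluorophenyl in place of 2,4-dichlorophenyl on the sulfur gives a 1.1-fold lower number from compound 2 to compound 4 (0.03 log units; within the scatter), and (4-fluorophenyl)sulfanyl in place of cyclohexylmethoxy gives a 1.0-fold lower number from compound 1 to compound 4 (0.02 log units; within the scatter), so all three changes at these positions stay within the scatter. No measurement offered here accounts for these steps. As far as these compounds go, whether an amine or a carboxylic acid on that ring, or a longer chain in place of the sulfanyl group, would give a step beyond the scatter remains open.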